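Cyclopropylamino for pyrrolidinyl on a diaminopyrimidine urea

The source may report more compounds than this note shows. Statements on the series, on what has been measured and on what is new or still open speak of the compounds shown alone.

Compound 1 `Cc1cc(Cl)ccc1NC(=O)Nc1nc(NC2CC2)cc(Sc2c[nH]c3ccccc23)n1`: 14600 nM
Compound 2 `O=C(Nc1ccccc1)Nc1nc(Nc2ccccc2)cc(Sc2c[nH]c3ccccc23)n1`: 35900 nM
Compound 3 `O=C(Nc1ccccc1)Nc1nc(Sc2c[nH]c3ccccc23)cc(N2CCCC2)n1`: 7890 nM

In a functional assay on MDA-MB-231 cells (Homo sapiens) for inhibition, with a stated time of 72 h (on this read-out lower numbers stand for stronger inhibition and higher numbers for weaker inhibition), compound 3 gives the lowest of the three numbers. Compound 1 sits nearest to it, within the scatter, while compound 2 stands furthest away, beyond the scatter. Among the compounds with values here, the one measured step that runs on a single change is a 4.6-fold lower number from compound 2 to compound 3 (0.66 log units; beyond the scatter), a modest move that is nonetheless beyond the scatter.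

Compound 4 `O=C(Nc1ccccc1)Nc1nc(NC2CC2)cc(Sc2c[nH]c3ccccc23)n1` is not yet measured. It differs from compound 3 in one place: cyclopropylamino in place of pyrrolidin-1-yl on an aromatic carbon. This is the same position on the shared core that the measured step concerns, so that step bears on the question, although it compares different groups. Compound 1 already carries cyclopropylamino at this position, together with a different aryl on the urea, and in this assay compound 1 gives 14600 nM; compound 3 gives 7890 nM. The two values suggest that cyclopropylamino at this position yields a number of about the same order as pyrrolidin-1-yl, leaning towards a somewhat higher one. Compound 4 is therefore expected to lie a little above compound 3, a 1.5-fold higher number from compound 3 to compound 4 (0.18 log units; within the scatter), a step that may well stay within the scatter. The estimate for compound 4 is 12000 nM, with a range from 5000 nM to 30000 nM.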

Compound 4, half-maximal inhibitory concentration: 7860 nM
Compound 4: middle estimate off by 1.5-fold (0.18 log units), on the high side, and the stated range covers the measured number.
By their numbers in this assay, from the lowest: compounds 4, 3 and 1 (each within the scatter of the next); then compound 2.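

In this assay, cyclopropylamino and pyrrolidin-1-yl on this aromatic carbon cannot be told apart with the phenyl urea held fixed (a 1.0-fold lower number from compound 3 to compound 4 (0.00 log units; within the scatter)), even though cyclopropylamino carries a hydrogen-bond donor and pyrrolidin-1-yl does not. Compound 4 also separates from the anilino compound 2 (a 4.6-fold lower number from compound 2 to compound 4 (0.66 log units; beyond the scatter)), a step of the same size as the one already seen with pyrrolidin-1-yl (a 4.6-fold lower number from compound 2 to compound 3 (0.66 log units; beyond the scatter)), so among these compounds both non-aromatic groups part from anilino in the same direction, with none going against it. The urea aryl can now be read as well: phenyl in place of 4-chloro-2-methylphenyl stays within the scatter (a 1.9-fold lower number from compound 1 to compound 4 (0.27 log units; within the scatter)), so these two aryl groups cannot be separated at this level of activity.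

On these data alone, whether a six-membered ring amine such as piperidine or morpholine, or an open-chain amine such as dimethylamino, would fall with these two groups on the shared core remains open. No accompanying measurement speaks to what lies behind these numbers.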